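The compounds below may be only part of what the source reports. "The series", "measured", "known", "first", "only" and "open" are said of these compounds alone.

Of the compounds shown here, three built on one shared core have been measured in a functional assay on SiHa cells (Homo sapiens) for cytotoxicity; a higher number here means a weaker inhibitor, a lower number a stronger inhibitor. Compound 1 `CC(C)(C)c1cc(C(C)(C)C)c2oc(C(c3ccccc3)c3c[nH]c4ccccc34)cc2c1` gives 61600 nM in this assay. Compound 2 `Cc1[nH]c2ccccc2c1C(c1ccccc1)c1cc2cc(C(C)(C)C)cc(C(C)(C)C)c2o1` differs by a methyl in place of hydrogen on an aromatic carbon, and in this assay compound 2 gives 72000 nM; a 1.2-fold higher number from compound 1 to compound 2 (0.07 log units; within the scatter). Compound 3 `CC(C)(C)c1cc(C(C)(C)C)c2oc(C(c3ccccc3)c3c[nH]c4ccc([N+](=O)[O-])cc34)cc2c1` carries a nitro in place of hydrogen on an aromatic carbon, and in this assay compound 3 gives 48200 nM. Compared with the others, a 1.3-fold lower number from compound 1 to compound 3 (0.11 log units; within the scatter) and a 1.5-fold lower number from compound 2 to compound 3 (0.17 log units; within the scatter), so compound 3 stands within the scatter of both compound 1 and compound 2.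

Compound 4 `COc1ccc(C(c2cc3cc(C(C)(C)C)cc(C(C)(C)C)c3o2)c2c[nH]c3ccc([N+](=O)[O-])cc23)cc1` takes the step (methoxy in place of hydrogen on an aromatic carbon). Among the compounds with values here, no measured step touches this phenyl ring; the steps seen so far, all small substituent changes elsewhere on the core, each stayed within the scatter. On that basis no step beyond the scatter is expected, and a 1.0-fold lower number from compound 3 to compound 4 (0.00 log units; within the scatter) is the estimated change. Compound 4 is therefore expected to give about 48000 nM in this assay, with a range from 20000 nM to 115000 nM.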

Compound 4, half-maximal inhibitory concentration: > 100000 nM
Compound 4 gave a limit, no number (the forecaster's own chance of this, stated with the estimate: 15%); middle value at least 2.0-fold (0.31 log units) from the limit.
By their numbers in this assay, from the lowest: compounds 3, 1 and 2 (each within the scatter of the next). At a limit, above all of these: compound 4.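

Methoxy in place of hydrogen, para to a large group on the phenyl ring, is the first change at this position, and it gives the first step beyond the scatter in this assay: an at least 2.0-fold higher number from compound 3 to compound 4 (0.31 log units; beyond the scatter). The methyl and nitro changes elsewhere on the shared core all stayed within the scatter, so phenyl to 4-methoxyphenyl is the only change shown that moves the number beyond it. Compound 4 stands at a limit of the assay and not at a number, so the full size of this step cannot be read: the limit of > 100000 nM in this assay, at which 1 of the 4 values shown sits.

The compounds shown leave open whether a hydroxyl, a chlorine or an amine at this place would shift the number as methoxy does. They also leave open whether methoxy gives a similar step on compound 1, which has no nitro.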